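Replacing the nitrile end of the side chain in compound 1

A few compounds are considered here, and "the series" means these few. Any claim that something is new, unique, unknown or untested is made for them only; others in the source may bear on it.

Compound 1, with the structure `CCc1cc(C(C)=O)c(O)cc1OCCCCC#N`, gives 57% in an assay on isolated protein for binding affinity to leukotriene B4 receptor 1 (Homo sapiens), tested at 1 uM; a lower number here means less inhibition, a higher number more inhibition at the concentration tested (going by the name of the read-out). It stands highest of the three measured compounds: compound 2 `CCCc1cc(C(C)=O)c(O)cc1OCCCCC#N` gives 37%, and compound 3 `CCCCCc1cc(C(C)=O)c(O)cc1OCCCCC#N` gives 14%. The measured steps are a number 20 percentage points lower from compound 1 to compound 2 (beyond the scatter), a number 43 percentage points lower from compound 1 to compound 3 (beyond the scatter) and a number 23 percentage points lower from compound 2 to compound 3 (beyond the scatter); all of them lengthen the alkyl chain on the ring and leave the cyano-terminated chain untouched.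

Compound 4, with the structure `CCc1cc(C(C)=O)c(O)cc1OCCCC(C)(C)C(N)=O`, differs from compound 1 at the other end of the molecule: 1-carbamoyl-1-methylethyl in place of cyanomethyl on a saturated chain carbon, three bonds along the chain from an oxygen on an aromatic ring. Going by the values given here, none of the measured steps bears on this position, so the three steps give no direction for it. The expectation therefore leans on the value of compound 1 alone, with wide uncertainty in both directions.

Compound 4 is estimated to give 45% in this assay, within a range from 15% to 75%. The step this implies is expected to be a number 12 percentage points lower from compound 1 to compound 4 (beyond the scatter).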

Compound 4, a percentage reported as inhibition, at one concentration (the size of the read-out at that concentration, not a potency): 51%
Beside the measured number, compound 4's estimate is 6 percentage points below it; low and high end bracket the measured number.
By their numbers in this assay, from the lowest: compound 3; then compound 2; then compounds 4 and 1 (each within the scatter of the next).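

In this assay, this is the first step shown at the far end of the side chain, and it lies within the scatter: a number 6 percentage points lower from compound 1 to compound 4 (within the scatter). So at this position, on a saturated chain carbon, three bonds along the chain from an oxygen on an aromatic ring, the nitrile can give way to 1-carbamoyl-1-methylethyl without a step beyond the scatter, unlike the lengthening of the ring alkyl chain, where the read-out shows a number 20 percentage points lower from compound 1 to compound 2 (beyond the scatter). No measurement offered here explains this result.

On these data alone, it remains open whether the carbamoyl group or the methyl groups matter more here, and whether a carboxylic acid, an amine or a tetrazole in this place would give a similar number. As far as these compounds go, it also remains open whether this replacement would hold on the longer ring chains of compound 2 and compound 3.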